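From Hydroxy to Dimethylamino: Expectation for Compound 3

The compounds below may be only part of what the source reports. "The series", "measured", "known", "first", "only" and "open" are said of these compounds alone.

Compound 1, `COc1ccc(/C=N\NC(=S)NC(C)(C)CCC[C@](C)(O)[C@@H]2CC=C(C)CC2)cc1`: in a functional assay on NCI-H460 cells (Homo sapiens) for cytotoxicity, read by sulforhodamine B assay (a higher number here means that more compound is tolerated, a lower number that less compound is tolerated), compound 1 reaches only the assay's limit of > 100000 nM.
Compound 2, `CC1=CC[C@@H]([C@@](C)(O)CCCC(C)(C)NC(=S)N/N=C\c2ccc(O)cc2)CC1`: in this assay compound 2 likewise reaches only the limit of > 100000 nM.

For the measured compounds named here, compound 2 thus stands at a limit rather than at a number, and the one further value shown is a limit as well. Going by the values given here, the single measured step, a step that the two limits leave unreadable from compound 1 to compound 2, has no readable size: the limit of > 100000 nM in this assay, at which 2 of the 2 values shown sit.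

Compound 3, `CC1=CC[C@@H]([C@@](C)(O)CCCC(C)(C)NC(=S)N/N=C\c2ccc(N(C)C)cc2)CC1`, differs from compound 2 by dimethylamino in place of hydroxy on an aromatic carbon. Among the compounds with values here, no measured step with a readable size bears on this change, so there is nothing to point to a rise or a fall in this assay. Compound 3 is therefore expected to sit at about 100000 nM, within 30000 nM to 300000 nM, and most likely to be reported again as a limit. The expected step of a number no higher from compound 2 to compound 3 (the limit leaves the size open) is estimated as none beyond the scatter.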

Compound 3, concentration lethal to 50% of the cells: > 100000 nM
Compound 3 gave a limit, no number (the forecaster's own chance of this, stated with the estimate: 70%); the middle value sits exactly at the limit.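

For the compounds shown here, compound 1, compound 2 and compound 3 all stop at one limit, so no step among them can be read in this assay: the limit of > 100000 nM in this assay, at which 3 of the 3 values shown sit.

What stays open is whether methoxy, hydroxy and dimethylamino differ at all in how much compound is tolerated, since none of these compounds has a number.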